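The source may report more compounds than this note shows. Statements on the series, on what has been measured and on what is new or still open speak of the compounds shown alone.

Three compounds share a core in which a biphenyl-like fragment is joined through an oxygen-bearing linker to a small ring holding two nitrogens or a nitrogen and an oxygen. Compound 1 `Cc1ccc(-c2ccccc2OC(C)C2=NCCN2)cc1` has a methyl-bearing outer ring, and in an assay on CHO cells for displacement of a labelled ligand from Alpha-2C adrenergic receptor (Homo sapiens) (a lower number here means a stronger inhibitor, a higher number a weaker inhibitor), compound 1 gives 251 nM. Compound 3 `CC(Oc1ccccc1-c1ccccc1[N+](=O)[O-])C1=NCCN1` carries a nitro group on its outer ring, and in this assay compound 3 gives 1230 nM. Compound 2 `CC(Oc1ccccc1-c1ccccc1)C1=NCCO1` differs in more than one place, and in this assay compound 2 gives 5890 nM. Compound 1 thus shows the lowest number of the three, with compound 3 the nearest and compound 2 the furthest, both beyond the usual scatter.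

Compound 4 `CC(Oc1ccccc1-c1cccs1)C1=NCCN1` differs from compound 1 in a single place: thiophen-2-yl in place of 4-methylphenyl on an aromatic carbon. Among the compounds with values here, no measured pair shows this change. A modest weakening is expected, with the step from compound 1 to compound 4 estimated at a 2.0-fold higher number from compound 1 to compound 4 (0.30 log units; within the scatter). Compound 4 is therefore expected to give 500 nM, within a range from 150 nM to 1800 nM.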

Compound 4, inhibition constant: 72.4 nM
Beside the measured number, compound 4's estimate is 6.9-fold (0.84 log units) above it; the measured number lies below the stated range.
By their numbers in this assay, from the lowest: compound 4; then compound 1; then compound 3; then compound 2.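

In this assay, putting thiophen-2-yl in place of 4-methylphenyl on this aromatic carbon gives a 3.5-fold lower number from compound 1 to compound 4 (0.54 log units; beyond the scatter), a step beyond the scatter, so a six-membered aromatic ring of carbon only is not needed here for a low number. The entering ring has 5 heavy atoms against 7 and brings a sulfur and one hydrogen-bond acceptor, but this single pair cannot tell which of these differences matters. No measurement at hand explains the gain in strength.

On these data alone, whether furan-2-yl, with oxygen in the place of sulfur, or a pyridine ring would reach as low a number at this position remains open. As far as these compounds go, it is also open how an open chain such as n-butyl would compare with these aromatic rings.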